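The source may report more compounds than this note shows. Statements on the series, on what has been measured and on what is new or still open speak of the compounds shown alone.

Compounds measured so far in an assay on membranes from HEK293 cells for displacement of a labelled ligand from Type-2 angiotensin II receptor (Homo sapiens), read by radioligand binding; a lower number here means a stronger inhibitor, a higher number a weaker inhibitor:

compound 1, `CCCCOC(=O)NS(=O)(=O)c1ccc(CCC)cc1-c1ccc(Cn2c(CC(C)C)nc3ccccc32)cc1`: 19 nM
compound 2, `CCCCOC(=O)NS(=O)(=O)c1ccc(CCC)cc1-c1ccc(Cn2c(Cc3ccccc3)nc3ccccc32)cc1`: 15 nM
compound 3, `CCCCOC(=O)NS(=O)(=O)c1ccc(CCC)cc1-c1ccc(Cn2c(CC)nc3ccccc32)cc1`: 11 nM

All three share the same core and differ only in the group on the saturated chain carbon bound to an aromatic carbon of the fused ring. Compound 3 has the lowest of the three numbers, but none of the gaps separates it: a 1.7-fold lower number from compound 1 to compound 3 (0.24 log units; within the scatter), a 1.4-fold lower number from compound 2 to compound 3 (0.13 log units; within the scatter), and between the other two a 1.3-fold lower number from compound 1 to compound 2 (0.10 log units; within the scatter). On these numbers compound 3 cannot be called more potent than compound 1 or compound 2; the three sit together.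

Compound 4, `CCCCOC(=O)NS(=O)(=O)c1ccc(CCC)cc1-c1ccc(Cn2c(C3CC3)nc3ccccc32)cc1`, is the next member, differing from compound 3 as follows: cyclopropyl in place of ethyl on an aromatic carbon. The three measured steps all bear on this change, since each of them swaps the substituent at this same point of the fused ring, from isopropyl to phenyl, isopropyl to methyl and phenyl to methyl, and each lay within the scatter. Going by the values given here, no measured step here moved the number beyond the scatter, so the expectation for compound 4 in this assay is no step beyond the scatter, a 1.2-fold higher number from compound 3 to compound 4 (0.07 log units; within the scatter). Compound 4 is therefore estimated at 13 nM, with a range from 6 nM to 28 nM.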

Compound 4, inhibition constant: 31 nM
Compound 4: the middle estimate sits 2.4-fold (0.38 log units) below what was measured; the whole stated range lies below it.
By their numbers in this assay, from the lowest: compounds 3, 2, 1 and 4 (each within the scatter of the next, the first and the last beyond it).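

In this assay, the position on the aromatic carbon between two ring nitrogen atoms now gives its first steps beyond the scatter, both modest: cyclopropyl in place of ethyl (a 2.8-fold higher number from compound 3 to compound 4 (0.45 log units; beyond the scatter)) and cyclopropyl in place of benzyl (a 2.1-fold higher number from compound 2 to compound 4 (0.32 log units; beyond the scatter)). The same place is therefore not wholly indifferent to its substituent, although the separation is incomplete: cyclopropyl in place of isobutyl (a 1.6-fold higher number from compound 1 to compound 4 (0.21 log units; within the scatter)) stays within the scatter, so compound 1 goes against any clean split of cyclopropyl from the three open-chain or benzyl groups. Nothing available accounts for these steps.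

The compounds shown do not tell whether the steps follow from the three-membered ring itself or from the ring carbon standing directly on the aromatic carbon, a question that isopropyl, cyclobutyl or a propyl chain at this place would help to settle. Also open, as far as these compounds go, is how this place responds to groups carrying a heteroatom, such as an amine or a carboxylic acid, and whether the ethyl to cyclopropyl step holds with other groups elsewhere on the shared core.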